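The source may hold more compounds than are shown below. What is called first, only, known or untested is meant among the compounds shown, and "the series" means these compounds.

For the measured compounds named here, compound 2 `CC(C)(C)c1ccc(C(=O)N2CCC3(CC2)C(=O)N(CC(=O)NCCCCCNS(C)(=O)=O)CN3c2ccccc2)cc1` stands at the lower end of the two numbers so far: in an assay on HEK293 cells for displacement of a labelled ligand from NPC1-like intracellular cholesterol transporter 1 (Homo sapiens) (a lower number here means a stronger inhibitor, a higher number a weaker inhibitor), compound 2 gives 5500 nM, while compound 1 `CC(C)(C)OC(=O)NCCCCCNC(=O)CN1CN(c2ccccc2)C2(CCN(C(=O)c3ccc(C(C)(C)C)cc3)CC2)C1=O` gives 13700 nM in this assay. Going by the values given here, the single measured step, a 2.5-fold lower number from compound 1 to compound 2 (0.40 log units; beyond the scatter), came from methylsulfonyl in place of tert-butoxycarbonyl on an amine nitrogen.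

Compound 3 `CC(C)(C)c1ccc(C(=O)N2CCC3(CC2)C(=O)N(CC(=O)N2CCCCC2CO)CN3c2ccccc2)cc1` differs from compound 2 by 2-(hydroxymethyl)piperidin-1-yl in place of (5-(methanesulfonamido)pentyl)amino on a carbonyl carbon. Among the compounds with values here, this change removes the whole (5-(methanesulfonamido)pentyl)amino group rather than exchanging its end, so the step from compound 1 to compound 2 does not bear on it directly; no measured step covers the entry of a ring at this carbonyl carbon. With nothing to point in either direction, the expected change is small, with an estimated step of a 1.1-fold lower number from compound 2 to compound 3 (0.04 log units; within the scatter) carrying wide uncertainty. Compound 3 is therefore expected to give about 5000 nM in this assay, within a range of 1500 nM to 16000 nM.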

Compound 3, half-maximal inhibitory concentration: 11800 nM
Compound 3: middle estimate off by 2.4-fold (0.37 log units), on the low side; low and high end bracket the measured number.
By their numbers in this assay, from the lowest: compound 2; then compounds 3 and 1 (each within the scatter of the next).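

Exchanging the whole (5-(methanesulfonamido)pentyl)amino group on this carbonyl carbon for 2-(hydroxymethyl)piperidin-1-yl brings a 2.1-fold higher number from compound 2 to compound 3 (0.33 log units; beyond the scatter) in this assay and so shows that the number responds to the group as a whole at this place, not only to the exchange on the amine nitrogen seen earlier. The change is modest, and here a ring-bearing group with fewer heavy atoms goes with the weaker inhibitor of the pair. Nothing available explains this step.

The compounds shown leave open whether the step follows from the entry of the ring or from the loss of the methanesulfonamido end. They also leave open how a plain piperidin-1-yl group without the hydroxymethyl, or a pentyl chain ending in a carboxylic acid, would stand at this carbonyl carbon.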